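Isopropyl for pyridin-3-yl on the amide nitrogen

The compounds below may be only part of what the source reports. "The series", "measured", "known", "first", "only" and "open" are said of these compounds alone.

Measured in an in vitro ADME assay on microsomes from liver (Mus musculus) for pharmacokinetics, read by LC-MS, with a stated time of 10 min, tested at 1 uM; a higher number here means faster removal of the compound, a lower number slower removal:
- compound 1 (`CN1C[C@H](C(=O)Nc2ccccc2)[C@@H](c2ccc(/C=C/C(=O)Nc3ccccc3N)cc2)C1`): 67 mL/min/kg
- compound 2 (`Cc1cc(NC(=O)[C@H]2CN(C)C[C@@H]2c2ccc(/C=C/C(=O)Nc3ccccc3N)cc2)ccc1Cl`): 65 mL/min/kg
- compound 3 (`CN1C[C@H](C(=O)Nc2cccnc2)[C@@H](c2ccc(/C=C/C(=O)Nc3ccccc3N)cc2)C1`): 41 mL/min/kg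

In this assay compound 3 gives 41 mL/min/kg, a value within the usual scatter of those of compound 1 and compound 2. Compound 4 (`CC(C)NC(=O)[C@H]1CN(C)C[C@@H]1c1ccc(/C=C/C(=O)Nc2ccccc2N)cc1`) differs from compound 3 at one place, with isopropyl in place of pyridin-3-yl on an amide-type nitrogen.

For the measured compounds named here, three measured steps bear on this place: a 1.6-fold lower number from compound 1 to compound 3 (0.21 log units; within the scatter), a 1.6-fold lower number from compound 2 to compound 3 (0.20 log units; within the scatter) and a 1.0-fold lower number from compound 1 to compound 2 (0.01 log units; within the scatter). All three stay within the scatter. Each of these compounds carries a six-membered aromatic ring on that nitrogen, however, and none carries a group without a ring, so these steps guide the new change only loosely. No step beyond the scatter is therefore expected, though the range is kept wide. The expected change is a 1.2-fold higher number from compound 3 to compound 4 (0.09 log units; within the scatter). For compound 4 the estimated clearance is 50 mL/min/kg, with an expected range of 25 mL/min/kg to 95 mL/min/kg.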

Compound 4, clearance: 12 mL/min/kg
Compound 4: middle estimate off by 4.2-fold (0.62 log units), on the high side; the whole stated range lies above it.
By their numbers in this assay, from the lowest: compound 4; then compounds 3, 2 and 1 (each within the scatter of the next).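

In this assay the group on the amide-type nitrogen turns out to move the number beyond the scatter, which the ring-bearing compounds alone never showed: isopropyl in place of pyridin-3-yl gives a 3.4-fold lower number from compound 3 to compound 4 (0.53 log units; beyond the scatter) and isopropyl in place of 4-chloro-3-methylphenyl gives a 5.4-fold lower number from compound 2 to compound 4 (0.73 log units; beyond the scatter) while isopropyl in place of phenyl gives a 5.6-fold lower number from compound 1 to compound 4 (0.75 log units; beyond the scatter) and so all three steps run the same way. Compound 4, the only one of the four without a ring on that nitrogen, has the lowest number, with its steps to all the others beyond the scatter. Nothing measured here explains this drop.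

Going by these compounds, whether the lower number follows from losing the ring or belongs to isopropyl itself stays open, and cyclopropyl, cyclohexyl or a longer chain such as n-butyl on the same nitrogen would separate the two. On these data alone, how an amine or a carboxylic acid carried on such a chain would read in this assay also remains open.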